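Cycloheptyl for pyridin-3-yl on the saturated ring carbon

This account rests on a few compounds, and the source may have more. Where it says the series, first, only, none or still open, it means among the compounds named here.

In a functional assay on MCF7 cells (Homo sapiens) for cytotoxicity, read by WST assay, with a stated time of 72 h (a higher number here means a weaker inhibitor, a lower number a stronger inhibitor), compound 1 `Cc1ccc(C2(c3ccc(O)cc3)C(=O)Nc3c2ccc(F)c3F)cc1` gives 1.7 nM, and compound 2 `O=C1Nc2c(ccc(F)c2F)C1(c1ccc(O)cc1)c1cccnc1` gives 63 nM, the higher of the two single numbers. Within the data shown here, the one measured step, a 37-fold higher number from compound 1 to compound 2 (1.57 log units; beyond the scatter), is large and lies beyond the scatter, so the group on this saturated ring carbon can move the number strongly. The next change leads to compound 4 `O=C1Nc2c(ccc(F)c2F)C1(c1ccc(O)cc1)C1CCCCCC1`: cycloheptyl in place of pyridin-3-yl on a saturated ring carbon. The expectation of a lower number in this assay rests on compound 3 `O=C1Nc2c(ccc(F)c2F)C1(c1ccc(O)cc1)C1CCCCC1`, which also carries a non-aromatic ring of carbon only at that place and shows 13 nM; 18 nM; > 1000 nM (3 entries). The entry of compound 3 with a sign is a limit of the assay and not a number. The expected move is moderate, at a 2.9-fold lower number from compound 2 to compound 4 (0.46 log units; beyond the scatter). For compound 4 the estimate is 22 nM, with an expected range from 5 nM to 150 nM.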

Compound 4, half-maximal inhibitory concentration: 1.2 nM
The estimate for compound 4 lay 18-fold (1.26 log units) above the measured number, outside the stated range (below it).
By their numbers in this assay, from the lowest: compounds 4 and 1 (each within the scatter of the next); then compound 2.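

In this assay, a 53-fold lower number from compound 2 to compound 4 (1.72 log units; beyond the scatter), so this saturated ring carbon does not need an aromatic ring to give a low number: cycloheptyl, a seven-membered non-aromatic ring of carbon only, serves there. Against the aromatic carbon ring of the first compound, the change gives a 1.4-fold lower number from compound 1 to compound 4 (0.15 log units; within the scatter), so 4-methylphenyl and cycloheptyl cannot be told apart in this assay, and of the groups with a single number only pyridin-3-yl stands apart. Compound 3 gives no single number to set beside these, and one of its entries is a limit of the assay and not a number: the several entries of compound 3 in this assay, 13 nM; 18 nM; > 1000 nM (3 entries)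

Whether the ring nitrogen of pyridin-3-yl accounts for its step remains open, since no compound here separates that atom from the rest of the group. From the compounds shown here alone, it is also open how an open chain such as n-heptyl, or a ring carrying an amine such as piperidin-4-yl, would behave at this carbon.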